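Methylation of the phenolic hydroxy in compound 2

This account rests on a few compounds, and the source may have more. Where it says the series, first, only, none or still open, it means among the compounds named here.

Two compounds of the series carry numbers in an assay on Cerebral cortex (strain Sprague-Dawley) for displacement of a labelled ligand from Neuronal acetylcholine receptor; alpha4/beta2 (Rattus norvegicus); on this read-out higher numbers stand for weaker inhibition and lower numbers for stronger inhibition. Compound 1 `CN1CCC[C@H]1[C@@H]1COc2ccc(Br)cc2O1` gives 8100 nM in this assay. Among the compounds with values here, compound 2 `CN1CCC[C@H]1[C@@H]1COc2ccc(O)cc2O1` gives 12 nM in this assay, the lowest of the two numbers, and the only step measured so far is a 680-fold lower number from compound 1 to compound 2 (2.83 log units; beyond the scatter). Compound 3 `COc1ccc2c(c1)O[C@H]([C@@H]1CCCN1C)CO2` has not yet been measured in this assay. The change from compound 2 to compound 3 is methyl in place of hydrogen on an oxygen on an aromatic ring. Within the data shown here, no measured step alters the oxygen-bearing substituent of compound 2 in this way, so there is no direct precedent. Among the measured compounds shown here, what the single step of a 680-fold lower number from compound 1 to compound 2 (2.83 log units; beyond the scatter) does show is that the group on this aromatic carbon moves the number very strongly, with the hydroxy giving the low number. Capping that hydroxy with methyl removes the donor hydrogen that compound 2 carries at this place, so the number for compound 3 is expected to rise beyond the scatter, though by less than the bromo-to-hydroxy step. Compound 3 is estimated at 200 nM, with a range from 30 nM to 1500 nM. The expected step is therefore a 17-fold higher number from compound 2 to compound 3 (1.22 log units; beyond the scatter).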

Compound 3, inhibition constant: 17000 nM
Compound 3: middle estimate off by 85-fold (1.93 log units), on the low side; measured number above the stated range.
By their numbers in this assay, from the lowest: compound 2; then compound 1; then compound 3.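

In this assay a single methyl on the oxygen removes the low number that compound 2 holds, with a 1400-fold higher number from compound 2 to compound 3 (3.15 log units; beyond the scatter) as the step, so an oxygen on this aromatic carbon is not enough on its own to give that number. The methoxy also gives no gain over the bromo: a 2.1-fold higher number from compound 1 to compound 3 (0.32 log units; beyond the scatter) is a modest step, though beyond the scatter, and it leaves compound 3 with the highest number of the three. Across these compounds the low number therefore goes only with the free hydroxy, and of the groups shown neither methoxy nor bromo comes close to it, but nothing measured here says why.

The compounds shown leave open whether any other group on this aromatic carbon, such as an amine, a hydroxymethyl or a carboxylic acid, can restore a low number in this assay as the hydroxy does. They also leave open how the number responds to a longer chain on the oxygen, such as ethyl, and whether the hydroxy has the same weight when the rest of the core is changed.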